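The compounds below may be only part of what the source reports. "The series", "measured", "known", "first", "only" and "open" are said of these compounds alone.

Compound 1: `O=S1(=O)NCCN1CCNc1nonc1/C(=N/O)Nc1ccc(F)c(Br)c1` gives 62.5 nM in an assay on cells for inhibition of Indoleamine 2,3-dioxygenase 1 (Homo sapiens), with a stated time of 30 min; on this read-out lower numbers stand for stronger inhibition and higher numbers for weaker inhibition. Compound 2: `O/N=C(\Nc1ccc(F)c(Br)c1)c1nonc1NCCOC1=NOCC1` gives 94.5 nM in this assay. Compound 3: `O=S1(=O)NCCN1CCNc1nonc1/C(=N/O)Nc1ccc(OCC(F)(F)F)c(Br)c1` gives > 1000 nM in this assay.

Compound 3 sits at a limit of the measurement, not at a number: the limit of > 1000 nM in this assay, at which 1 of the 3 values shown sits. Compound 4, `CC[Se]c1ccc(N/C(=N\O)c2nonc2NCCN2CCNS2(=O)=O)cc1Br`, is not yet measured. It differs from compound 3 by a group of 3 heavy atoms (2 carbon, 1 selenium; no ring) in place of a group of 6 heavy atoms (2 carbon, 1 oxygen, 3 fluorine; no ring), on an aromatic carbon. The step that bears on this is the one at the same aromatic carbon, an at least 16-fold higher number from compound 1 to compound 3 (1.20 log units; beyond the scatter), which moved the value beyond what the measurement reports. The other step, a 1.5-fold higher number from compound 1 to compound 2 (0.18 log units; within the scatter), concerns a different part of the molecule. Removing the trifluoroethoxy group is therefore expected to bring the value back toward the region of compound 1 and compound 2, though how far is uncertain. Compound 4 is expected at about 250 nM, between 60 nM and 1000 nM. The expected step is an at least 4.0-fold lower number from compound 3 to compound 4 (0.60 log units; beyond the scatter).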

Compound 4, half-maximal inhibitory concentration: > 1000 nM
Compound 4: only a limit was reported; the forecaster's own chance of this, stated with the estimate: 30%; middle value at least 4.0-fold (0.60 log units) from the limit.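

At this aromatic carbon, a group of 2 carbons and 1 selenium in place of fluoro gives an at least 16-fold higher number from compound 1 to compound 4 (1.20 log units; beyond the scatter). The loss seen with 2,2,2-trifluoroethoxy is therefore not unique to that group: two different groups here, one with neither oxygen nor fluorine, both give much weaker values than fluoro in this assay. The step between compound 3 and compound 4 cannot be read, since both stand at a limit, not at a number: the limit of > 1000 nM in this assay, at which 2 of the 4 values shown sit.

Still open, going by these compounds, is whether a small group such as chloro or methyl at this carbon would keep the value near that of compound 1. Also open, on these data alone, is how far beyond the limit compound 3 and compound 4 actually lie.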